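Methyl in place of ring hydrogen on a bis-aziridinyl quinone

The source may report more compounds than this note shows. Statements on the series, on what has been measured and on what is new or still open speak of the compounds shown alone.

The compounds measured so far:
compound 1, `CC1=C(N2CC2)C(=O)C(C(C)COC(N)=O)=C(N2CC2)C1=O`, 5.71
compound 2, `CCC(OC)C1=C(N2CC2)C(=O)C(C)=C(N2CC2)C1=O`, 5.33
compound 3, `CC(C)C1=C(N2CC2)C(=O)C=C(N2CC2)C1=O`, 5.37

All three share a core with two aziridin-1-yl groups and differ in the side groups on the ring. In a functional assay on L1210 cells (Mus musculus), with a stated time of 12 days (a higher number here means a more potent compound, by a factor of ten per unit of this negative logarithm, a lower number a less potent compound), compound 3 gives 5.37, the second highest of the three numbers. Compound 2, at 5.33, lies within the scatter of compound 3, so the two cannot be told apart. Compound 1, at 5.71, stands above compound 3 by more than the scatter.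

Compound 4, `CC1=C(N2CC2)C(=O)C(C(C)C)=C(N2CC2)C1=O`, is compound 3 with a single change: methyl in place of hydrogen on a double-bonded ring carbon.

Among the measured compounds shown here, the only measured step, a number 0.38 log units lower from compound 1 to compound 2 (beyond the scatter), concerns a different part of the molecule, a replacement of one side chain by another, and does not involve a methyl entering for a hydrogen. For the measured compounds named here, there is therefore no measured step that bears on this change. Compounds 1 and 2 both carry a methyl at this position and span a range around compound 3, which gives no clear direction. The expected step of a number 0.13 log units higher from compound 3 to compound 4 (within the scatter) is thus small, within the scatter. For compound 4 the estimate in this assay is 5.5, with a range from 5.1 to 5.9.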

Compound 4, logarithm of the reciprocal of the active concentration, log(1/C): 5.21
For compound 4 the middle estimate is 0.29 log units above the measured one, and the stated range covers the measured number.
By their numbers in this assay, from the lowest: compounds 4, 2 and 3 (each within the scatter of the next); then compound 1.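

In this assay, methyl and hydrogen on this double-bonded ring carbon cannot be told apart with an isopropyl group on the shared core: the step is a number 0.16 log units lower from compound 3 to compound 4 (within the scatter). Exchanging the side chain while the methyl stays in place gives the same kind of result for isopropyl in place of 1-methoxypropyl, with a number 0.12 log units lower from compound 2 to compound 4 (within the scatter). Among the compounds shown here, the one step here that can be read as a real difference lies in the side chain rather than at the new methyl: hydrogen in place of carbamoyloxy on the saturated chain carbon gives a number 0.50 log units lower from compound 1 to compound 4 (beyond the scatter), which joins the earlier a number 0.38 log units lower from compound 1 to compound 2 (beyond the scatter) in setting compound 1 apart from the two compounds it is paired with. No measurement at hand gives a reason for these numbers.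

The compounds shown leave open whether an ethyl group, a methoxy group or an amine on this ring carbon would differ from hydrogen by more than the scatter. They also leave open whether the carbamoyloxy side chain would give a similar step with hydrogen rather than methyl on this ring carbon.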